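This account rests on a few compounds, and the source may have more. Where it says the series, first, only, none or still open, it means among the compounds named here.

Among the measured compounds shown here, in an ADME assay on A549 cells (Homo sapiens) for cytotoxicity, read by resazurin assay, with a stated time of 48 h (a higher number here means that more compound is tolerated, a lower number that less compound is tolerated), only two related compounds have numbers so far. Compound 1 `O=C(Nc1ccc(NCC2CC2)cc1Cl)c1cc(Cl)ccc1O` gives 14400 nM, while compound 2 `CC1(Nc2ccc(NC(=O)c3cc(Cl)ccc3O)c(Cl)c2)CCCC1` gives 157000 nM, the higher of the two and so the better tolerated of this pair. For the measured compounds named here, the only measured step is an 11-fold higher number from compound 1 to compound 2 (1.04 log units; beyond the scatter). It is large and beyond the scatter, and in it 1-methylcyclopentyl takes the place of cyclopropylmethyl on a nitrogen on an aromatic ring.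

Compound 3 `O=C(Nc1ccc(NC2CCCCC2)cc1Cl)c1cc(Cl)ccc1O` keeps the shared core and changes that same group: cyclohexyl in place of 1-methylcyclopentyl on a nitrogen on an aromatic ring. Cyclohexyl therefore replaces 1-methylcyclopentyl, with the same atoms joined differently. Going by the values given here, the measured step bears on this change only indirectly: it shows that swapping the group on this nitrogen can shift the number substantially, but no measured compound carries cyclohexyl. Among the compounds with values here, compound 2 has the highest number so far, and compound 1 at 14400 nM is the only lower reference, so a moderate move toward a lower number is expected, smaller than the measured step. The expected change is a 3.5-fold lower number from compound 2 to compound 3 (0.54 log units; beyond the scatter). For compound 3, the estimated value is 45000 nM, with an expected range from 12000 nM to 160000 nM.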

Compound 3, half-maximal cytotoxic concentration: 68300 nM
Compound 3: middle estimate off by 1.5-fold (0.18 log units), on the low side; the measured number falls inside the stated range.
By their numbers in this assay, from the lowest: compound 1; then compound 3; then compound 2.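

Cyclohexyl and 1-methylcyclopentyl contain the same atoms, yet swapping one for the other on this nitrogen gives a 2.3-fold lower number from compound 2 to compound 3 (0.36 log units; beyond the scatter), so in this assay the number depends on more than which atoms the group contains. Against the third group, cyclohexyl in place of cyclopropylmethyl gives a 4.7-fold higher number from compound 1 to compound 3 (0.68 log units; beyond the scatter), which places compound 3 between the other two and shows that a second ring group directly on this nitrogen goes with a higher number than cyclopropylmethyl. No measurement shown here explains why the three groups fall in this order.

Among the compounds shown here, with only three groups at this position, it remains open where a plain cyclopentyl ring, a cyclobutyl ring or a longer open chain such as hexyl would fall, and whether an added amine or carboxylic acid on the group would change the order. Going by these compounds, it is also open whether the same order would hold if the chlorine atoms or the hydroxyl group on the shared core were replaced, since all three compounds carry them unchanged.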